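The compounds below may be only part of what the source reports. "The series", "measured", "known", "first", "only" and "open" are said of these compounds alone.

Measured so far in a functional assay on HepG2 cells (Homo sapiens) for cytotoxicity, read by MTT assay, with a stated time of 72 h; on this read-out lower numbers stand for stronger inhibition and higher numbers for weaker inhibition:
- compound 1, `O=C(Nc1ccc(Oc2ccnc3[nH]ccc23)c(F)c1)c1nn(-c2ccc(Cl)cc2)ccc1=O`: > 60000 nM
- compound 2, `Cn1ccc2c(Oc3ccc(NC(=O)c4nn(-c5ccc(Cl)cc5)ccc4=O)cc3)ccnc21`: > 60000 nM

Both measured compounds sit at the limit of this assay. Compound 1 gives > 60000 nM, which is a limit and not a number. Compound 2 likewise gives > 60000 nM, again a limit and not a number. Within the data shown here, compound 2 therefore stands at the same limit as the only other value shown; the evidence amounts to the limit of > 60000 nM in this assay, at which 2 of the 2 values shown sit, so no measured step is available and no ordering of the two can be read from these values.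

Compound 3, `Cn1ccc2c(Oc3ccc(NC(=O)c4nn(-c5ccc(Cl)cc5)ccc4=O)cc3F)ccnc21`, is the next member. It differs from compound 2 by fluoro in place of hydrogen on an aromatic carbon. Compound 1 already carries the same fluoro on the same ring and shows only a limit, while compound 2 without it also shows only a limit. Among the measured compounds shown here, no step between measured compounds exists to size this change, so no shift beyond the scatter is expected in this assay.

The estimate for compound 3 is 80000 nM, range 30000 nM to 250000 nM. The expected step from compound 2 is a step that the limit leaves unreadable from compound 2 to compound 3, in effect none, and most likely this assay again reports only a limit for compound 3.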

Compound 3, half-maximal inhibitory concentration: > 60000 nM
Compound 3: only a limit was reported (the forecaster's own chance of this, stated with the estimate: 85%); the middle value is on the limit's open side.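

In this assay compound 3 gives > 60000 nM, which is a limit. The steps from compound 2 and from compound 1 to compound 3 therefore cannot be read: the limit of > 60000 nM in this assay, at which 3 of the 3 values shown sit. The compounds shown leave open whether fluoro in place of hydrogen on an aromatic carbon, or methyl in place of hydrogen on an aromatic nitrogen, changes the activity at all.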